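Furan-3-yl for phenyl on the shared core

The source may hold more compounds than are shown below. What is called first, only, known or untested is meant among the compounds shown, and "the series" means these compounds.

Measured so far:
compound 1, `CCC(c1ccccc1)c1nc(-c2ccc(Cl)cc2)c(CC(=O)O)s1`, gives 190 nM in an in vitro assay on HEK385-7 cells for displacement of a labelled ligand from prostaglandin D2 receptor 2 (Homo sapiens); a higher number here means a weaker inhibitor, a lower number a stronger inhibitor
compound 2, `O=C(O)Cc1sc(C(c2ccc(F)cc2)c2ccc(F)cc2)nc1-c1ccccc1`, gives 16 nM in this assay

Compound 2 holds the lower of the two numbers. Within the data shown here, compound 1 is the only other measured compound, and its number is higher by a margin that lies beyond the usual scatter; the two differ in more than one place, so no single step between them is available.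

Compound 3, `O=C(O)Cc1sc(C(c2ccc(F)cc2)c2ccc(F)cc2)nc1-c1ccoc1`, has not yet been measured in this assay. It differs from compound 2 in one place: furan-3-yl in place of phenyl on an aromatic carbon

Among the measured compounds shown here, no step between measured compounds is known, so nothing measured here shows how this change acts on the shared core. The exchange keeps an aromatic ring of similar size at the same position, and the rest of compound 2 is unchanged. A small step is expected, slightly toward a higher number, or none beyond the scatter. The expected step is a 1.6-fold higher number from compound 2 to compound 3 (0.19 log units; within the scatter). Compound 3 is therefore estimated at 25 nM in this assay, within a range of 8 nM to 80 nM.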

Compound 3, half-maximal inhibitory concentration: 14 nM
The estimate for compound 3 lay 1.8-fold (0.25 log units) above the measured number; measured number inside the range.
By their numbers in this assay, from the lowest: compounds 3 and 2 (each within the scatter of the next); then compound 1.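

In this assay the exchange of phenyl for furan-3-yl, on the aromatic carbon next to the ring nitrogen, gives a 1.1-fold lower number from compound 2 to compound 3 (0.06 log units; within the scatter) and so leaves compound 3 and compound 2 indistinguishable within the scatter. Among these compounds, this is the first single-place step on the shared core, and it shows that at this position a five-membered aromatic ring with 1 hetero atom can stand in for a six-membered aromatic ring of carbon only without a shift beyond the scatter, even though the exchange also adds a hydrogen-bond acceptor and removes one heavy atom. Nothing available on these compounds bears on why the number stays within the scatter.

The compounds shown leave open whether this position also accepts a non-aromatic group, such as an amine, a piperidine ring or a longer alkyl chain, or a different aromatic ring, such as furan-2-yl or pyridyl. Compound 1 differs from compound 2 in more than one place, so the effect of its chlorophenyl group at this position remains unresolved on its own.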